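Shifting the hydroxyl onto a branched carbon in the ester chain

A few compounds are considered here, and "the series" means these few. Any claim that something is new, unique, unknown or untested is made for them only; others in the source may bear on it.

Compound 2 `CCCC(O)CC(=O)O[C@H](CC=C(C)C)C1=CC(=O)c2c(O)ccc(O)c2C1=O` was tested in a functional assay on HeLa cells (Homo sapiens) for cytotoxicity, read by MTT assay (a lower number here means a stronger inhibitor, a higher number a weaker inhibitor), and gives 59300 nM. Among the three measured compounds it stands second highest: compound 1 `CC(C)=CC[C@@H](OC(=O)CCO)C1=CC(=O)c2c(O)ccc(O)c2C1=O` gives 67600 nM, and a 1.1-fold lower number from compound 1 to compound 2 (0.06 log units; within the scatter); compound 3 `CC(C)=CC[C@@H](OC(=O)CC(C)(O)C(C)C)C1=CC(=O)c2c(O)ccc(O)c2C1=O` gives 27700 nM, and a 2.1-fold lower number from compound 2 to compound 3 (0.33 log units; beyond the scatter). Compound 4 `CC[C@@](C)(O)CC(=O)O[C@H](CC=C(C)C)C1=CC(=O)c2c(O)ccc(O)c2C1=O` differs from compound 2 by 1-hydroxy-1-methylpropyl in place of 1-hydroxybutyl on a saturated chain carbon bound to a carbonyl carbon. The closest guide is a 2.1-fold lower number from compound 2 to compound 3 (0.33 log units; beyond the scatter), where 1-hydroxy-1,2-dimethylpropyl entered at the same place; a 2.4-fold lower number from compound 1 to compound 3 (0.39 log units; beyond the scatter) points the same way. Compound 3 carries 1-hydroxy-1,2-dimethylpropyl, whereas 1-hydroxy-1-methylpropyl is the group entering here. A smaller downward step is expected for compound 4, a 1.4-fold lower number from compound 2 to compound 4 (0.15 log units; within the scatter). Compound 4 is therefore estimated at 42000 nM, within 21000 nM to 84000 nM.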

Compound 4, half-maximal inhibitory concentration: 17900 nM
Beside the measured number, compound 4's estimate is 2.3-fold (0.37 log units) above it; the measured number lies below the stated range.
By their numbers in this assay, from the lowest: compounds 4 and 3 (each within the scatter of the next); then compounds 2 and 1 (each within the scatter of the next).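

Swapping 1-hydroxybutyl for 1-hydroxy-1-methylpropyl keeps the same atoms, yet in this assay it gives a 3.3-fold lower number from compound 2 to compound 4 (0.52 log units; beyond the scatter), so how these atoms are joined matters at this place, not only their number. The step of a 1.5-fold lower number from compound 3 to compound 4 (0.19 log units; within the scatter) leaves the two branched groups indistinguishable, while a 3.8-fold lower number from compound 1 to compound 4 (0.58 log units; beyond the scatter) sets the new group clearly apart from the shorter unbranched chain as well. No supporting data explain these differences. Still open, from the compounds shown here alone, is whether a longer chain on the same carbon would lower the number further, and whether an amine could replace the hydroxyl.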